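Swapping ethyl for trifluoromethyl on the aryl of compound 1

This account rests on a few compounds, and the source may have more. Where it says the series, first, only, none or still open, it means among the compounds named here.

Measured compounds:
compound 1, `CCc1ccc(N2C(=O)C=CC2OCC(F)(F)F)cc1`, 4470 nM
compound 2, `O=C1C=CC(OC(C(F)(F)F)C(F)(F)F)N1c1ccc(Cl)cc1`, 4480 nM
compound 3, `O=C1C=CC(OCC(F)(F)F)N1c1cc(F)cc(F)c1`, 520 nM

Of the compounds shown here, three sharing one core have been tested in a functional assay on K562 cells (Homo sapiens) for inhibition; on this read-out lower numbers stand for stronger inhibition and higher numbers for weaker inhibition. Compound 1 gives 4470 nM, and compound 2 gives 4480 nM, a value that lies within the scatter of that of compound 1, so the two cannot be ordered. Compound 3 gives 520 nM, a lower number than compound 1 by a margin that lies beyond the scatter. Compound 1 thus stands with compound 2 at the higher end of the three numbers, while compound 3 sits well apart from both.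

The next compound, compound 4, `O=C1C=CC(OCC(F)(F)F)N1c1ccc(C(F)(F)F)cc1`, is not yet measured in this assay. It is reached from compound 1 by a single change: trifluoromethyl in place of ethyl on an aromatic carbon. Among the compounds with values here, no step between two measured compounds isolates this particular change, so the expectation rests only on the three numbers above. In this assay the step is expected to be small, estimated as a 1.5-fold lower number from compound 1 to compound 4 (0.17 log units; within the scatter), leaning toward a lower number without clearly leaving the scatter. For compound 4 the value is therefore estimated at 3000 nM, with a range from 1000 nM to 9000 nM.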

Compound 4, half-maximal inhibitory concentration: 13100 nM
The estimate for compound 4 lay 4.4-fold (0.64 log units) below the measured number; measured number outside the range, above it.
By their numbers in this assay, from the lowest: compound 3; then compounds 1 and 2 (each within the scatter of the next); then compound 4.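

In this assay trifluoromethyl in place of ethyl, on an aromatic carbon para to a large group, gives a 2.9-fold higher number from compound 1 to compound 4 (0.47 log units; beyond the scatter) and so moves the read-out beyond the scatter toward weaker inhibition. Within the data shown here, this is the first step that isolates a single change, and it shows that this position of the six-membered aromatic ring does not treat the two groups alike, even though neither group carries a hydrogen-bond donor, a hydrogen-bond acceptor or a net charge. No measurement of any property of the two groups is at hand that bears on this result, so the step stands as an observation without an explanation.

Among these compounds, with only one step at this position, the compounds leave open whether ethyl is favoured in its own right or whether trifluoromethyl alone is disfavoured, and a methoxy group, a nitrile, an amine or a longer chain such as propyl at the same carbon would help to separate the two. They also leave open whether the same swap would have a similar effect on a compound carrying the ether side chain of compound 2 instead of that of compound 1.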